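This account rests on a few compounds, and the source may have more. Where it says the series, first, only, none or still open, it means among the compounds named here.

Compound 1 `COc1cc2ncnc(Nc3ccc(F)c(Cl)c3)c2cc1NC(=O)N/N=C/c1ccc(OC)c(OC)c1OC`: 29300 nM
Compound 2 `COc1cc2ncnc(Nc3ccc(F)c(Cl)c3)c2cc1NC(=O)N/N=C/c1cc(OC)c(OC)c(OC)c1`: 36500 nM
Compound 3 `COc1cc2ncnc(Nc3ccc(F)c(Cl)c3)c2cc1NC(=O)N/N=C/c1ccc(O)c(Br)c1`: 15300 nM

All three values come from a functional assay on PC-3 cells (Homo sapiens) for cytotoxicity, read by MTT assay, with a stated time of 72 h; a lower number here means a stronger inhibitor, a higher number a weaker inhibitor. Compound 3 has the lowest number, but its lead is small: the data show a 1.9-fold lower number from compound 1 to compound 3 (0.28 log units; within the scatter) and a 2.4-fold lower number from compound 2 to compound 3 (0.38 log units; beyond the scatter).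

The next compound is compound 4 `COc1cc2ncnc(Nc3ccc(F)c(Cl)c3)c2cc1NC(=O)N/N=C/c1ccc(O)cc1`. The change is hydrogen in place of bromo on an aromatic carbon, ortho to a hydroxy group, turning 3-bromo-4-hydroxyphenyl into 4-hydroxyphenyl.

Among the measured compounds shown here, no measured step isolates the bromo. The two steps above replace the whole substituted phenyl group, and neither is large, so no large step is expected in this assay. A slight drift to a higher number is the likeliest outcome, since the other two compounds sit no lower than compound 3, and it may not clear the scatter. The expected step is a 1.4-fold higher number from compound 3 to compound 4 (0.16 log units; within the scatter). For compound 4 the estimated value is 22000 nM, with an expected range of 10000 nM to 45000 nM.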

Compound 4, half-maximal inhibitory concentration: 16600 nM
Estimate against measurement, compound 4: 1.3-fold (0.12 log units) above; the range from low to high includes it.
By their numbers in this assay, from the lowest: compounds 3, 4, 1 and 2 (each within the scatter of the next, the first and the last beyond it).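

In this assay, among the compounds shown here, hydrogen in place of bromo is the first change of a single atom on this aryl group, and it leaves the read-out within the scatter (a 1.1-fold higher number from compound 3 to compound 4 (0.04 log units; within the scatter)). Compound 4 shows that the 4-hydroxyphenyl group without the bromo still gives a modest step beyond the scatter against the 3,4,5-trimethoxyphenyl group (a 2.2-fold lower number from compound 2 to compound 4 (0.34 log units; beyond the scatter)), while against the 2,3,4-trimethoxyphenyl group the step stays within it (a 1.8-fold lower number from compound 1 to compound 4 (0.25 log units; within the scatter)). Nothing measured here offers an explanation for these steps.

Still open, going by these compounds, is whether chloro, methoxy or an amine in place of the bromo would shift the read-out at all. Also open, on these data alone, is what an unsubstituted phenyl or a 4-methoxyphenyl group would give in place of 4-hydroxyphenyl, which would test the hydroxy group itself.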